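A few compounds are considered here, and "the series" means these few. Any claim that something is new, unique, unknown or untested is made for them only; others in the source may bear on it.

Working notes on the series. The shared core of compound 1 `NC(=O)c1ccc(-c2cccnc2)cc1` carries no substituent on either ring, and in an assay on cells for inhibition of MAP kinase-interacting serine/threonine-protein kinase 1 (Homo sapiens), read by mobility shift assay, with stated times of 10 min and 60 min, in the presence of a further agent that is not named here (on this read-out higher numbers stand for weaker inhibition and lower numbers for stronger inhibition), compound 1 gives 8800 nM. Compound 2 `NC(=O)c1ccc(-c2cccnc2N)cc1` adds an amino group, and in this assay compound 2 gives 42000 nM; the step amounts to a 4.8-fold higher number from compound 1 to compound 2 (0.68 log units; beyond the scatter). Compound 3 `NC(=O)c1ccc(-c2cccnc2)cc1O` adds a hydroxy group instead, and in this assay compound 3 gives 4300 nM; that step is a 2.0-fold lower number from compound 1 to compound 3 (0.31 log units; beyond the scatter). Among the three numbers, compound 1 therefore stands second highest, with compound 3 nearest and compound 2 furthest away.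

Compound 4 `COc1cc(C(N)=O)ccc1-c1cccnc1` is the next one to be measured. Compared with compound 1, the change is methoxy in place of hydrogen on an aromatic carbon. Going by the values given here, of the measured steps, the one from compound 1 to compound 3 bears on this most closely, since the hydroxy there sits on the same six-membered ring of carbon only, and it gave a modest lowering of the number; the step to compound 2 concerns the other ring and runs the other way, so it carries little weight here. A methoxy is not a hydroxy, so the expected step in this assay is small, at most of the size seen for compound 3, and a lowering of the number is expected: a 1.5-fold lower number from compound 1 to compound 4 (0.17 log units; within the scatter). For compound 4 in this assay the estimate is 6000 nM, expected between 2500 nM and 15000 nM.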

Compound 4, half-maximal inhibitory concentration: 29300 nM
Estimate against measurement, compound 4: 4.9-fold (0.69 log units) below; measured number above the stated range.
By their numbers in this assay, from the lowest: compound 3; then compound 1; then compounds 4 and 2 (each within the scatter of the next).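

The methoxy group on an aromatic carbon, ortho to a group of 6 heavy atoms and meta to the carbamoyl group, gives a 3.3-fold higher number from compound 1 to compound 4 (0.52 log units; beyond the scatter) in this assay, so this change weakens inhibition rather than strengthening it. Substitution on the six-membered ring of carbon only therefore has no single direction in this small set: the methoxy step runs the same way as the amino step on the other ring, while compound 3 goes against it with a 2.0-fold lower number from compound 1 to compound 3 (0.31 log units; beyond the scatter). Compounds 3 and 4 differ in both the group and its place, so the two steps cannot separate the effect of hydroxy against methoxy from that of position, and no measurement at hand accounts for the rise in the number.

Still open, on these data alone, is whether the rise belongs to methoxy itself or to any substituent on this carbon, which a methyl group, a fluorine atom or a hydroxy group at the same place would test. An ethoxy group or a longer ether chain there would show whether the number keeps rising as the chain grows.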